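Chloro to methylsulfanyl on a potent methoxy compound

A few compounds are considered here, and "the series" means these few. Any claim that something is new, unique, unknown or untested is made for them only; others in the source may bear on it.

Compound 1 `CSc1ccc(-c2nc3cc[nH]cc-3n2)cc1`: 4 mg/kg
Compound 2 `COc1cc(Cl)ccc1-c1nc2cc[nH]cc-2n1`: 0.23 mg/kg

In a functional assay on the whole organism with Canis familiaris (Canis lupus familiaris) as the target (a lower number here means that less compound is needed, a higher number that more compound is needed for the effect), compound 2 holds the lower of the two numbers, 0.23 mg/kg, beyond the scatter from compound 1. Compound 3 `COc1cc(SC)ccc1-c1nc2cc[nH]cc-2n1` follows from compound 2 with methylsulfanyl in place of chloro on an aromatic carbon. Within the data shown here, no measured pair isolates this change, so the expectation is uncertain. Compound 3 keeps the methoxy group of compound 2, and no change beyond the scatter is expected in this assay. The expected step is a 1.1-fold higher number from compound 2 to compound 3 (0.04 log units; within the scatter). For compound 3 the estimated value is 0.25 mg/kg, with an expected range of 0.07 mg/kg to 0.9 mg/kg.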

Compound 3, dose for half-maximal effect: 0.2 mg/kg
The estimate for compound 3 lay 1.3-fold (0.10 log units) above the measured number; the measured number falls inside the stated range.
By their numbers in this assay, from the lowest: compounds 3 and 2 (each within the scatter of the next); then compound 1.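

In this assay, the position para to the group of 9 heavy atoms takes methylsulfanyl in place of chloro with a 1.2-fold lower number from compound 2 to compound 3 (0.06 log units; within the scatter) on the methoxy compounds, so these two groups are not told apart here. Among these compounds, compound 3 also isolates the methoxy group for the first time: with methylsulfanyl held in place, the step is a 20-fold lower number from compound 1 to compound 3 (1.30 log units; beyond the scatter) and it is large. On these data alone, whether an amine or a longer chain at the methylsulfanyl position would keep this level stays open, as does whether methoxy gives a similar step with chloro in place. No available evidence bears on either step.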